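Replacing hydroxy with methylamino in a small series

The source may report more compounds than this note shows. Statements on the series, on what has been measured and on what is new or still open speak of the compounds shown alone.

In a functional assay on MCF7 cells (Homo sapiens) for antiproliferative activity, read by MTT assay, with a stated time of 48 h (a lower number here means a stronger inhibitor, a higher number a weaker inhibitor), compound 1 `COc1ccc(C(=O)c2ccc(OC)c3c2OC(C)(C)C=C3)c(NC(=O)CBr)c1` gives 2360 nM as its reading, and compound 2 `COc1ccc(C(=O)c2ccc(OC)c3c2OC(C)(C)C=C3)c(NC(=O)CO)c1` gives 320 nM on the same core. Exchanging bromo for hydroxy thus amounts to a 7.4-fold lower number from compound 1 to compound 2 (0.87 log units; beyond the scatter) in this pair. Compound 3 `COc1ccc(C(=O)c2ccc3c(c2)C=CC(C)(C)O3)c(NC(=O)CO)c1` carries the same hydroxy group on a core that differs from that of compound 2. At 200 nM compound 3 stands level with compound 2 within the scatter, and its number lies well under that of compound 1.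

Compound 4 `CNCC(=O)Nc1cc(OC)ccc1C(=O)c1ccc2c(c1)C=CC(C)(C)O2` keeps the core of compound 3 and differs thus: methylamino in place of hydroxy on a saturated chain carbon bound to a carbonyl carbon with methylamino in place of hydroxy on a saturated chain carbon bound to a carbonyl carbon. Going by the values given here, only the step from bromo to hydroxy concerns this place. Among the compounds with values here, it shows that the number can move with the group there, but no measured compound carries methylamino, so neither its size nor its direction carries over directly. The estimate therefore starts from compound 3 and allows for a wide range. The expected change is a 1.5-fold higher number from compound 3 to compound 4 (0.18 log units; within the scatter) in this estimate, so no step beyond the scatter is expected in this assay at the middle value. For compound 4 the estimated value is 300 nM with an expected range from 90 nM to 1000 nM in this assay.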

Compound 4, half-maximal inhibitory concentration: 1210 nM
The estimate for compound 4 lay 4.0-fold (0.61 log units) below the measured number, outside the stated range (above it).
By their numbers in this assay, from the lowest: compounds 3 and 2 (each within the scatter of the next); then compounds 4 and 1 (each within the scatter of the next).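

In this assay, methylamino in place of hydroxy on a saturated chain carbon bound to a carbonyl carbon gives a 6.1-fold higher number from compound 3 to compound 4 (0.78 log units; beyond the scatter), so this place responds to a change other than the earlier exchange of bromo for hydroxy, and the two groups exchanged here are close in what is counted for them: each brings one hydrogen-bond donor, one hydrogen-bond acceptor and no net charge. Together with a 7.4-fold lower number from compound 1 to compound 2 (0.87 log units; beyond the scatter), on a different core, the new step means that in both pairs read at this place the compound with hydroxy has the lower number, so neither replacement tried for hydroxy matches it, although only two pairs support this pattern and no compound goes against it. Nothing among the data shown explains why methylamino raises the number, and no cause can be assigned to this step.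

The compounds shown leave open whether a plain amino group, a dimethylamino group, a carboxylic acid or a longer chain ending in hydroxy would keep the number of compound 3 at this place. They also leave open whether methylamino would give a step of similar size on the core of compound 2.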